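Shorter Tellurium Chains and Cytotoxicity

The source may report more compounds than this note shows. Statements on the series, on what has been measured and on what is new or still open speak of the compounds shown alone.

- Compound 1 `O=S(=O)(O)OCCCCCCCCCCCC[Te]c1ccccc1`: 19800 nM
- Compound 2 `O=S(=O)(O)OCCCCCCCCC[Se]c1ccccc1`: > 100000 nM (a limit of the assay, not a number)
- Compound 3 `O=S(=O)(O)OCCCCCCCCCCC[Te]c1ccccc1`: 9730 nM

In a functional assay on HCT-116 cells (Homo sapiens) for cytotoxicity, read by MTT assay, with a stated time of 24 h (on this read-out lower numbers stand for stronger inhibition and higher numbers for weaker inhibition), compound 3 has the lowest number, 9730 nM, and compound 1 lies nearest to it. Compound 4 `O=S(=O)(O)OCCCCCCCCC[Te]c1ccccc1` has sulfooxy in place of 2-(sulfooxy)ethyl on a saturated chain carbon, nine bonds along the chain from a tellurium atom. For the measured compounds named here, one measured step bears on this change: with sulfooxy in place of (sulfooxy)methyl, there was a 2.0-fold lower number from compound 1 to compound 3 (0.31 log units; beyond the scatter). That single modest step suggests a small further fall in the number, but it is thin evidence. The expected change is a 1.2-fold lower number from compound 3 to compound 4 (0.09 log units; within the scatter). Compound 4 is estimated at 8000 nM, within a range of 2500 nM to 30000 nM.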

Compound 4, half-maximal inhibitory concentration: 4990 nM
Estimate against measurement, compound 4: 1.6-fold (0.20 log units) above, within the range that was stated.
By their numbers in this assay, from the lowest: compounds 4 and 3 (each within the scatter of the next); then compound 1. At a limit, above all of these: compound 2.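

Removing 2-(sulfooxy)ethyl in favour of sulfooxy gives a 1.9-fold lower number from compound 3 to compound 4 (0.29 log units; within the scatter), so this last shortening alone cannot be told from noise, but the tellurium compounds taken end to end show a 4.0-fold lower number from compound 1 to compound 4 (0.60 log units; beyond the scatter) and none of the three goes against that direction. With the chain held the same, tellurium in place of selenium gives an at least 20-fold lower number from compound 2 to compound 4 (1.30 log units; beyond the scatter), the first sign that the heavier atom matters. Compound 2 is a limit and not a number: the limit of > 100000 nM in this assay, at which 1 of the 4 values shown sits.

Going by these compounds, whether a still shorter chain continues the direction remains open. So does the effect of a carboxylic acid in place of sulfooxy.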